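A few compounds are considered here, and "the series" means these few. Any claim that something is new, unique, unknown or untested is made for them only; others in the source may bear on it.

Measured compounds, efficacy in an in vitro functional assay on HEK285-7 cells for antagonist activity at prostaglandin D2 receptor 2 (Homo sapiens), read by BRET and beta-arrestin recruitment; a higher number here means a larger maximal response, a lower number a smaller maximal response:
compound 1, `O=C(O)Cc1sc(COc2ccc(Cl)cc2)nc1-c1ccc(Cl)cc1`: 50%
compound 2, `CCC(c1ccccc1)c1nc(-c2ccc(Cl)cc2)c(CC(=O)O)s1`: 50%
compound 3, `O=C(O)Cc1sc(C(c2ccc(F)cc2)c2ccc(F)cc2)nc1-c1cc(F)cc(F)c1`: 80%

Compound 3 gives the highest maximal response of the three in this assay; compound 1, its nearest neighbour, and compound 2, the furthest, both lie lower by margins beyond the usual scatter. Among the measured compounds shown here, no pair of measured compounds differs in only one place, so no measured step is available.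

Compound 4, `O=C(O)Cc1sc(C(c2ccc(F)cc2)c2ccc(F)cc2)nc1-c1ccnc(N2CCC2)c1`, is not yet measured. It differs from compound 3 by 2-(azetidin-1-yl)pyridin-4-yl in place of 3,5-difluorophenyl on an aromatic carbon. With no single-point comparison at this position in this assay, only a modest move is expected, downward rather than upward, and of a size near the edge of the scatter.

For compound 4 the expected efficacy in this assay is 65%, in the range 45% to 90%.

This estimate implies an expected step of a number 15 percentage points lower from compound 3 to compound 4 (beyond the scatter).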

Compound 4, largest response reached (reported as efficacy), in percent of the reference or control that the assay uses: 80%
Beside the measured number, compound 4's estimate is 15 percentage points below it; the range from low to high includes it.
By their numbers in this assay, from the lowest: compounds 1 and 2 (each within the scatter of the next); then compounds 3 and 4 (each within the scatter of the next).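

Replacing 3,5-difluorophenyl with 2-(azetidin-1-yl)pyridin-4-yl on this aromatic carbon gives no change at the digits printed from compound 3 to compound 4 (within the scatter) in this assay as the read-out. This position therefore carries a larger group with a ring nitrogen, a four-membered ring and hydrogen-bond acceptors, where the leaving group has none, without a shift beyond the scatter. On these data alone, it remains open whether the azetidine ring or the pyridine nitrogen matters more, and how a morpholine or dimethylamino group in place of the azetidine would read. No measurement shown here bears on why the response holds.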